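Formyl to hydroxymethyl on the chain of compound 1

This account rests on a few compounds, and the source may have more. Where it says the series, first, only, none or still open, it means among the compounds named here.

Compound 1 `Cc1cn([C@H]2C[C@H](O)[C@@H](CO)O2)c(=O)n(/C=C/C=O)c1=O` gives 15000 nM in a functional assay on HeLa cells (Homo sapiens) for inhibition; on this read-out lower numbers stand for stronger inhibition and higher numbers for weaker inhibition. Compound 3 `O=C/C=C/n1c(=O)c(I)cn([C@H]2C[C@H](O)[C@@H](CO)O2)c1=O` gives 15000 nM, so that no change at the digits printed from compound 1 to compound 3 (within the scatter). For compound 2 `Cc1cn([C@@H]2O[C@H](CO)[C@@H](O)[C@H]2O)c(=O)n(/C=C/C=O)c1=O` only a limit is recorded, > 100000 nM, as noted in the limit of > 100000 nM in this assay, at which 1 of the 3 values shown sits. Accordingly an at least 6.6-fold higher number from compound 1 to compound 2 (0.82 log units; beyond the scatter). On these numbers compound 1 stands level with compound 3, within the scatter of that pair.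

Compound 4 `Cc1cn([C@H]2C[C@H](O)[C@@H](CO)O2)c(=O)n(/C=C/CO)c1=O` differs from compound 1 in one place: hydroxymethyl in place of formyl on a double-bonded chain carbon bound to a double-bonded chain carbon. Among the measured compounds shown here, neither measured step touches this chain; one varies a saturated ring carbon, the other an aromatic carbon, so no direct precedent exists. The expected step is a 2.7-fold higher number from compound 1 to compound 4 (0.43 log units; beyond the scatter), toward weaker inhibition, with considerable uncertainty. Compound 4 is therefore estimated at 40000 nM, within a range of 10000 nM to 150000 nM.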

Compound 4, half-maximal inhibitory concentration: > 100000 nM
Compound 4 gave a limit, no number (the forecaster's own chance of this, stated with the estimate: 40%); middle value at least 2.5-fold (0.39 log units) away from the limit.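

This is the first step shown on the chain, and it is beyond the scatter: hydroxymethyl in place of formyl gives an at least 6.6-fold higher number from compound 1 to compound 4 (0.82 log units; beyond the scatter). Among compounds 1 and 4, measurable inhibition in this assay therefore stays with the formyl group, so this place responds to a change that the earlier ring steps did not probe. The value of compound 4 is a limit and not a number, so the full size of the step stays unknown: the limit of > 100000 nM in this assay, at which 2 of the 4 values shown sit.

On these data alone, whether a carboxylic acid, an amine or a longer chain at this place would keep inhibition stays open. So does whether the same change would act alike on the iodo compound 3.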